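Compound 1 and a dimethoxy swap

The source may report more compounds than this note shows. Statements on the series, on what has been measured and on what is new or still open speak of the compounds shown alone.

Compound 1 `Cc1nc(-c2ccccc2F)c(C(=O)N2CCN(c3cc(Cl)cc(Cl)c3)CC2)s1` gives 157 nM in a functional assay on HL-60 cells (Homo sapiens) for inhibition, read by MTT assay, with a stated time of 72 h; on this read-out lower numbers stand for stronger inhibition and higher numbers for weaker inhibition
Compound 2 `Cc1nc(-c2ccc(Cl)cc2)c(C(=O)N2CCN(c3cccc(C(=O)C(C)C)c3)CC2)o1` reads "not active" (no number reported) in this assay

So far, compound 1 carries the only number in this assay and compound 2 has none to compare with it. That leaves a single point of reference and no ranking to speak of.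

Compound 3 `COc1cc(OC)cc(N2CCN(C(=O)c3sc(C)nc3-c3ccccc3F)CC2)c1` keeps the rest of compound 1 and swaps one group 3,5-dimethoxyphenyl in place of 3,5-dichlorophenyl on an amine nitrogen in a ring (in words, 3,5-dimethoxyphenyl in place of 3,5-dichlorophenyl on an amine nitrogen in a ring). Among the compounds with values here, no two measured compounds differ in just one place, so nothing yet shows what this swap does on its own in this assay and any forecast is rough. The starting point is compound 1 at 157 nM and a modest move towards weaker inhibition, meaning a higher number, is expected, though a result within the usual scatter would be no surprise. The estimated move is a 1.9-fold higher number from compound 1 to compound 3 (0.28 log units; within the scatter) and it carries wide uncertainty. The estimate for compound 3 is 300 nM (expected range 60 nM to 1500 nM).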

Compound 3, half-maximal inhibitory concentration: 96.8 nM
Estimate against measurement, compound 3: 3.1-fold (0.49 log units) above; the range from low to high includes it.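

Within the data shown here, this is the first pair in this assay that differs in one place only, and it gives a 1.6-fold lower number from compound 1 to compound 3 (0.21 log units; within the scatter), so on the amine nitrogen in the six-membered ring, 3,5-dimethoxyphenyl and 3,5-dichlorophenyl cannot be told apart on this read-out. The two groups are not close copies: the one that enters has 10 heavy atoms and 2 hydrogen-bond acceptors, while the one that leaves has 8 heavy atoms and 0 acceptors, yet the values of the pair stay within ordinary repeat variation. Nothing measured here gives a reason for this result.

Among these compounds, the pair shows only that these two groups read alike, so it remains open whether the same holds for a phenyl ring carrying an amine, a carboxylic acid or a longer alkoxy chain at this place. Compound 2 has no number and differs from the other compounds in more than one place, so it adds nothing to this question.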